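A few compounds are considered here, and "the series" means these few. Any claim that something is new, unique, unknown or untested is made for them only; others in the source may bear on it.

In an ADME assay on MT4 cells (Homo sapiens) for cytotoxicity, read by MTT assay (on this read-out higher numbers stand for lower toxicity in this test and lower numbers for higher toxicity in this test), compound 3 (`Cc1cc(C)cc(S(=O)(=O)c2c(C(=O)NCC(=O)NC(C)c3ccncc3)[nH]c3ccc(Cl)cc23)c1`) gives 47000 nM, the higher of the two actual numbers, and compound 1 (`Cc1cc(C)cc(S(=O)(=O)c2c(C(=O)NC(C)C(=O)NCCn3c(C)cnc3[N+](=O)[O-])[nH]c3ccc(Cl)cc23)c1`) gives 16000 nM. Compound 2 (`Cc1cc(C)cc(S(=O)(=O)c2c(C(=O)NCC(=O)NCc3ccncc3)[nH]c3ccc(Cl)cc23)c1`) gives only a limit, > 48900 nM. Compound 4 (`Cc1cc(C)cc(S(=O)(=O)c2c(C(=O)NCC(=O)NCCn3c(C)cnc3[N+](=O)[O-])[nH]c3ccc(Cl)cc23)c1`) departs from compound 3 by a group of 11 heavy atoms (6 carbon, 3 nitrogen, 2 oxygen; one five-membered aromatic ring with 2 hetero atoms) in place of a group of 8 heavy atoms (7 carbon, 1 nitrogen; one six-membered aromatic ring with 1 hetero atom), on an amide-type nitrogen. Within the data shown here, the one measured step, an at least 1.0-fold lower number from compound 2 to compound 3 (0.01 log units; that floor lies within the scatter), concerns a methyl in place of hydrogen, stays within the scatter, and offers little guidance on this larger exchange. The better guide is compound 1, which carries the same five-membered aromatic ring and gives 16000 nM. A move to a lower number in this assay is therefore expected, and the estimated step is a 2.4-fold lower number from compound 3 to compound 4 (0.37 log units; beyond the scatter). The expected value for compound 4 is 20000 nM, with an estimated range of 9000 nM to 45000 nM.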

Compound 4, half-maximal cytotoxic concentration: 24500 nM
Compound 4: the middle estimate sits 1.2-fold (0.09 log units) below what was measured, and the stated range covers the measured number.
By their numbers in this assay, from the lowest: compounds 1, 4 and 3 (each within the scatter of the next, the first and the last beyond it). At a limit, above all of these: compound 2.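

In this assay, the exchange of 1-(pyridin-4-yl)ethyl for the group with the five-membered aromatic ring, on the amide-type nitrogen, is a 1.9-fold lower number from compound 3 to compound 4 (0.28 log units; within the scatter), so even this larger change stays inside the scatter. Hydrogen in place of methyl on the chain carbon, a second reading of that small change, is a 1.5-fold higher number from compound 1 to compound 4 (0.19 log units; within the scatter). Compound 2 stands at a limit, and its step is an at least 1.9-fold lower number from compound 2 to compound 4 (0.30 log units; that floor lies within the scatter).

Going by these compounds, whether an amine or a carboxylic acid on the amide-type nitrogen would move the number beyond the scatter stays open. So does the outcome of a longer chain there.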